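A few compounds are considered here, and "the series" means these few. Any claim that something is new, unique, unknown or untested is made for them only; others in the source may bear on it.

Measured compounds in the series:

compound 1 `CCCCCc1ccc(C#Cc2ccc(C(=O)N3C[C@@H](O)C[C@H]3C(=O)NO)cc2)cc1` with 120 nM
compound 2 `O=C(NO)[C@@H]1C[C@H](O)CN1C(=O)c1ccc(C#Cc2ccc(OCCCCCF)cc2)cc1` with 108 nM

Compound 1 stands highest of the two numbers in an ADME assay on isolated protein for inhibition of matrix metalloproteinase-9 (Homo sapiens), read by fluorescence, with a stated time of 30 min (on this read-out lower numbers stand for stronger inhibition and higher numbers for weaker inhibition), its nearest neighbour being compound 2, which lies within the scatter of it. Among the measured compounds shown here, the one measured step, a 1.1-fold lower number from compound 1 to compound 2 (0.05 log units; within the scatter), exchanges a chain on an aromatic carbon and says nothing about the saturated ring.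

Compound 3 `CCCCCc1ccc(C#Cc2ccc(C(=O)N3C[C@H](O)C[C@H]3C(=O)NO)cc2)cc1` is the unmeasured member. Relative to compound 1 the change is the two compounds have the same atoms and bonds and differ only in configuration as drawn: 1 of 2 stereo elements differ; a stereocentre at a saturated ring carbon is drawn S in compound 1 and R in compound 3; the carbon in question is the one carrying the hydroxyl in the shared core. No measured step in this assay touches a stereocentre, so nothing shown bears directly on the change. The size of the step cannot be read from the data; in a pair that differs only in configuration as drawn, a change of either direction, or none beyond the scatter, remains possible. The working expectation is a moderate rise in number, estimated as a 2.1-fold higher number from compound 1 to compound 3 (0.32 log units; beyond the scatter), with a wide range that also covers a value within the scatter of compound 1.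

Compound 3 is therefore estimated at 250 nM, between 80 nM and 900 nM.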

Compound 3, half-maximal inhibitory concentration: 845 nM
For compound 3 the middle estimate is 3.4-fold (0.53 log units) below the measured one; the range from low to high includes it.
By their numbers in this assay, from the lowest: compounds 2 and 1 (each within the scatter of the next); then compound 3.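

In this assay, the stereocentre at the saturated ring carbon carrying the hydroxyl proves to matter, giving a 7.0-fold higher number from compound 1 to compound 3 (0.85 log units; beyond the scatter). Among the compounds shown here, this is the first step beyond the scatter, whereas the only earlier step, a 1.1-fold lower number from compound 1 to compound 2 (0.05 log units; within the scatter), exchanged a chain on an aromatic carbon and left the saturated ring as it was. With no group entering or leaving, the rise in number can be assigned to the configuration at that single carbon, with S drawn in the lower-numbered compound, because of this: the fact that compounds 1 and 3 differ only in the configuration as drawn

As far as these compounds go, the R configuration at this carbon appears here only with the chain of compound 1, so it remains open whether a step of similar size would hold with the chain of compound 2. Also open is how much of the step depends on the hydroxyl itself, since the compounds shown do not tell what a methoxy group, an amine or a fluorine on that carbon would give in either configuration.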